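From ethyl to methyl in a series held at a limit

A few compounds are considered here, and "the series" means these few. Any claim that something is new, unique, unknown or untested is made for them only; others in the source may bear on it.

Compound 2 (`CCn1c(/C=C2\SC(=O)N(CC(=O)N3CCc4cc(OC)c(OC)cc4C3)C2=O)nc2ccccc21`) gives > 50000 nM in a functional assay on DU-145 cells (Homo sapiens) for inhibition, read by MTT assay, with a stated time of 48 h (on this read-out higher numbers stand for weaker inhibition and lower numbers for stronger inhibition), and this value is a limit, not a number. Compound 1 (`CCn1c(/C=C2\SC(=O)N(CC(=O)Nc3cc(C(C)(C)C)on3)C2=O)nc2ccccc21`) gives > 50000 nM as a limit too. Compound 3 (`CCn1c(/C=C2\SC(=O)N(CC(=O)N3CC(C)OC(C)C3)C2=O)nc2ccccc21`) gives > 50000 nM as a limit as well. Within the data shown here, the whole picture so far is thus the limit of > 50000 nM in this assay, at which 3 of the 3 values shown sit, and no compound yet has a readable potency.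

Compound 4 (`COc1cc2c(cc1OC)CN(C(=O)CN1C(=O)S/C(=C\c3nc4ccccc4n3C)C1=O)CC2`) departs from compound 2 by hydrogen in place of methyl on a saturated chain carbon bound to an aromatic nitrogen and the change is hydrogen in place of methyl on a saturated chain carbon bound to an aromatic nitrogen, which turns ethyl to methyl. Among the measured compounds shown here, the only measured step, a step that the two limits leave unreadable from compound 1 to compound 3, lies on a carbonyl carbon, so it does not bear on this change and gives no size to carry over. No step beyond the scatter is therefore expected in this assay and no direction can be foreseen. The expected step is a number no higher from compound 2 to compound 4 (the limit leaves the size open) as an estimate only. Compound 4 is expected at 50000 nM within an estimated range of 20000 nM to 100000 nM and will most likely be reported as a limit again.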

Compound 4, half-maximal inhibitory concentration: 37500 nM
Compound 4: the middle estimate sits 1.3-fold (0.12 log units) above what was measured, and the stated range covers the measured number.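

In this assay, the change from ethyl to methyl gives an at least 1.3-fold lower number from compound 2 to compound 4 (0.12 log units; that floor lies within the scatter). Compound 4 thus brings the first readable number to the series, and this change on a saturated chain carbon bound to an aromatic nitrogen is the only one shown that ends in a number rather than a limit: the limit of > 50000 nM in this assay, at which 3 of the 4 values shown sit. Even so, the value for compound 2 is a limit, so the true size of this step stays open and its floor shows no change beyond the scatter, while the other step among these compounds cannot be read.

Going by these compounds, it remains open whether methyl in place of ethyl would give a readable number with the amide groups of compound 1 and compound 3. Also open, on these data alone, is what a propyl chain, or a longer chain ending in an amine or a carboxylic acid, would give in place of the ethyl.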